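Sulfonyl amide series: from compound 2 to compound 4

The source may hold more compounds than are shown below. What is called first, only, known or untested is meant among the compounds shown, and "the series" means these compounds.

compound 1 `O=C([C@@H]1CCCN(S(=O)(=O)c2ccc(S(=O)(=O)N3CC[C@@H](O)C3)cc2)C1)N1CCC(F)(F)CC1` gives 330 nM
compound 2 `CCN(CC)S(=O)(=O)c1ccc(S(=O)(=O)N2CCC[C@@H](C(=O)NC3CCOCC3)C2)cc1` gives 8570 nM
compound 3 `CN(C)S(=O)(=O)c1ccc(S(=O)(=O)N2CCC[C@@H](C(=O)N3CCC(F)(F)CC3)C2)cc1` gives 560 nM

All three values come from a functional assay on BXPC-3 cells (Homo sapiens) for inhibition, read by MTT assay, with a stated time of 7 days (on this read-out lower numbers stand for stronger inhibition and higher numbers for weaker inhibition), and compound 2 stands highest of them, at 8570 nM on that read-out. Compound 4 `CCN(CC)S(=O)(=O)c1ccc(S(=O)(=O)N2CCC[C@@H](C(=O)N3CC[C@@H](OC)C3)C2)cc1` differs from compound 2 by 3-methoxypyrrolidin-1-yl in place of (oxan-4-yl)amino on a carbonyl carbon with 3-methoxypyrrolidin-1-yl in place of (oxan-4-yl)amino on a carbonyl carbon. Among the compounds with values here, no measured step covers an exchange at this carbonyl carbon. Within the data shown here, the one step on hand, a 1.7-fold higher number from compound 1 to compound 3 (0.23 log units; within the scatter) on a sulfonyl sulfur, lies within the scatter and gives no size for the present change. Among the measured compounds shown here, the only other guide is the values: compound 1 stands at 330 nM and compound 3 at 560 nM with both well below compound 2, though neither carries the entering group. A lower number is therefore expected, beyond the scatter but with much uncertainty. The estimated change is a 4.3-fold lower number from compound 2 to compound 4 (0.63 log units; beyond the scatter) in this assay on this weak basis. For compound 4 the estimate is 2000 nM with an expected range from 500 nM to 8000 nM and no firmer figure can be expected from these data.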

Compound 4, half-maximal inhibitory concentration: 11500 nM
Beside the measured number, compound 4's estimate is 5.8-fold (0.76 log units) below it, and the stated range ends below it.
By their numbers in this assay, from the lowest: compounds 1 and 3 (each within the scatter of the next); then compounds 2 and 4 (each within the scatter of the next).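

In this assay, within the data shown here, 3-methoxypyrrolidin-1-yl in place of (oxan-4-yl)amino on a carbonyl carbon gives a 1.3-fold higher number from compound 2 to compound 4 (0.13 log units; within the scatter), the first measured step at this carbonyl carbon. On the core of compound 2, this position therefore accepts the exchange of the six-membered ring for the five-membered ring, the loss of the hydrogen-bond donor and the new defined stereocentre, with the step still within the scatter. No measurement on hand offers an explanation for this result.

Still open, on these data alone, is whether the same exchange stays within the scatter on the cores of compound 1 and compound 3, and whether the opposite stereocentre in the 3-methoxypyrrolidin-1-yl group matters. Also open, as far as these compounds go, is how a group of a different kind at this carbonyl carbon, such as a piperazine or a carboxylic acid on a longer chain, would read.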